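A few compounds are considered here, and "the series" means these few. Any claim that something is new, unique, unknown or untested is made for them only; others in the source may bear on it.

Working notes on the series. Compound 1 `CC(C)C(=O)O[C@H]1C[C@@H](C)C=C2C=C[C@H](C)[C@H](CC[C@@H]3C[C@@H](O)CC(=O)O3)C21` carries isopropyl on the ester carbonyl carbon; in an assay for inhibition of 3-hydroxy-3-methylglutaryl-coenzyme A reductase (Rattus norvegicus) (a higher number here means a weaker inhibitor, a lower number a stronger inhibitor), compound 1 gives 7.7 nM. Compound 2 `C=C(C)CC(=O)O[C@H]1C[C@@H](C)C=C2C=C[C@H](C)[C@H](CC[C@@H]3C[C@@H](O)CC(=O)O3)C21` carries 2-methylprop-2-en-1-yl in that place, and in this assay compound 2 gives 2.9 nM. Within the data shown here, the only measured step is a 2.7-fold lower number from compound 1 to compound 2 (0.42 log units; beyond the scatter). On these two numbers compound 2 stands at the lowest, with compound 1 its nearest neighbour at a higher value.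

Compound 3 `C[C@H]1C=C2C=C[C@H](C)[C@H](CC[C@@H]3C[C@@H](O)CC(=O)O3)C2[C@@H](OC(=O)c2ccc(F)cc2)C1` awaits measurement. It differs from compound 2 by 4-fluorophenyl in place of 2-methylprop-2-en-1-yl on a carbonyl carbon, the exchange taking place on a carbonyl carbon whose other neighbours are oxygen next to a carbonyl group. Among the measured compounds shown here, only the step of a 2.7-fold lower number from compound 1 to compound 2 (0.42 log units; beyond the scatter) bears on this change, and it concerns swapping one chain for another at the same carbonyl carbon; no measured step brings an aromatic ring into that position. That step was modest, and the present change is larger in count, so a step of similar size in either direction is plausible, with no firm basis to choose one. The value of compound 3 in this assay is estimated at 4 nM, within 1.2 nM to 15 nM. That estimate means an expected step of a 1.4-fold higher number from compound 2 to compound 3 (0.14 log units; within the scatter).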

Compound 3, half-maximal inhibitory concentration: 37 nM
Compound 3: the middle estimate sits 9.3-fold (0.97 log units) below what was measured, and the stated range ends below it.
By their numbers in this assay, from the lowest: compound 2; then compound 1; then compound 3.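

In this assay, among these compounds, this carbonyl carbon proves sensitive to the kind of group it carries: putting 4-fluorophenyl in place of 2-methylprop-2-en-1-yl gives a 13-fold higher number from compound 2 to compound 3 (1.11 log units; beyond the scatter) and is the largest step so far. Compared with the only earlier step, a 2.7-fold lower number from compound 1 to compound 2 (0.42 log units; beyond the scatter) between two open chains, the change to the aromatic ring is clearly larger, and the isopropyl comparison, a 4.8-fold higher number from compound 1 to compound 3 (0.68 log units; beyond the scatter) as well, runs in the same direction, leaving compound 3 with a higher number than either chain-bearing compound. No supporting data accompany these numbers to account for the difference between the ring and the chains.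

The compounds shown leave open whether the higher number goes with the aromatic ring itself or with its fluorine, a question that a plain phenyl group at the same carbonyl carbon would separate, while a benzyl group would show what a ring set further out does. Also open, as far as these compounds go, is whether the low number of compound 2 depends on its double bond, which the saturated 2-methylpropyl chain or a longer chain such as 3-methylbutyl would test.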